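Swapping a Dienoyl Cap for a Sulfonyl Cap

The compounds below may be only part of what the source reports. "The series", "measured", "known", "first", "only" and "open" are said of these compounds alone.

Compound 1 `C/C=C/C=C/C(=O)N[C@H](C(=O)NCCCCCCCCCCCC)[C@@H](C)O` in a functional assay on SiHa cells (Homo sapiens) for cytotoxicity, read by MTT assay, with a stated time of 48 h (a higher number here means a weaker inhibitor, a lower number a stronger inhibitor), gives > 200000 nM, a limit of the assay.
Compound 2 `CCCCCCCCCCCCNC(=O)[C@@H](NS(=O)(=O)c1ccc(C)cc1)[C@@H](C)O` in this assay gives 31600 nM.
Compound 3 `C/C=C/C=C/C(=O)N[C@H](C(=O)NCCCCCCCCCCCCCCCCCC)[C@@H](C)O` in this assay gives > 200000 nM, again a limit.

The change from compound 1 to compound 2 is (4-methylphenyl)sulfonyl in place of (penta-1,3-dien-1-yl)carbonyl on an amine nitrogen. It made an at least 6.3-fold lower number from compound 1 to compound 2 (0.80 log units; beyond the scatter), a step that rests on (the limit of > 200000 nM in this assay, at which 2 of the 3 values shown sit), so its true size is only bounded from one side. Compound 3 differs from compound 1 in the core alone: hexyl in place of hydrogen on a saturated chain carbon, ten or more bonds along the chain from an amide-type nitrogen. That gave a step that the two limits leave unreadable from compound 1 to compound 3, since both values sit at the limit of > 200000 nM in this assay, at which 2 of the 3 values shown sit.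

Compound 4 `CCCCCCCCCCCCCCCCCCNC(=O)[C@@H](NS(=O)(=O)c1ccc(C)cc1)[C@@H](C)O` is not yet measured. It stands to compound 3 as compound 2 stands to compound 1: (4-methylphenyl)sulfonyl in place of (penta-1,3-dien-1-yl)carbonyl on an amine nitrogen, the same change at the same place. The expected step for compound 4 is an at least 4.4-fold lower number from compound 3 to compound 4 (0.64 log units; beyond the scatter), a guess that rests on compound 2 with 31600 nM and on compound 1 with an at least 6.3-fold lower number from compound 1 to compound 2 (0.80 log units; beyond the scatter). Compound 4 is therefore estimated at 45000 nM, with a range from 15000 nM to 160000 nM, the long chain of compound 3 adding uncertainty.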

Compound 4, half-maximal inhibitory concentration: 29800 nM
Compound 4: the middle estimate sits 1.5-fold (0.18 log units) above what was measured; low and high end bracket the measured number.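

In this assay, the swap of (penta-1,3-dien-1-yl)carbonyl for (4-methylphenyl)sulfonyl on the amine nitrogen carried over to the core of compound 3 in the same direction, giving an at least 6.7-fold lower number from compound 3 to compound 4 (0.82 log units; beyond the scatter). Set beside the earlier step, the two read as follows: the same change on two cores in this assay, an at least 6.3-fold lower number (0.80 log units; beyond the scatter) from compound 1 to compound 2 and an at least 6.7-fold lower number (0.82 log units; beyond the scatter) from compound 3 to compound 4; the limit leaves it open whether they differ. The series therefore shows that the direction holds on both cores, but it does not show that the size of the step transfers, since each step starts from a limit and is bounded from one side only: the limit of > 200000 nM in this assay, at which 2 of the 4 values shown sit.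

As far as these compounds go, with the sulfonyl cap in place, the added hexyl on the chain gives a 1.1-fold lower number from compound 2 to compound 4 (0.03 log units; within the scatter), while the same chain change under the dienoyl cap cannot be read, so whether chain length matters with that cap stays open. Also open, from the compounds shown here alone, is whether the change would carry over to a shorter chain, or whether another cap, such as a benzoyl or a methanesulfonyl group, would behave like the (4-methylphenyl)sulfonyl group.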